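Ether side chain exchange on the shared core

The source may report more compounds than this note shows. Statements on the series, on what has been measured and on what is new or still open speak of the compounds shown alone.

For the measured compounds named here, compound 1 `Nc1ccc2cccc(OCC3CCCC3)c2n1` carries the only numeric value in this set: in an assay on cells with melanin-concentrating hormone receptor 1 (Homo sapiens) as the target, read by radioligand binding (a higher number here means a weaker inhibitor, a lower number a stronger inhibitor), compound 1 gives 53 nM. For compound 2 `CC(CC(C)(C)C)Oc1cccc2ccc(N3CCCCC3)nc12` only a limit is known, namely (the limit of > 2000 nM in this assay, at which 1 of the 2 values shown sits), recorded as > 2000 nM. Going by the values given here, compound 2 differs from compound 1 in more than one place, so no single step is counted between them. Compound 3 `CC(C)C(C)Oc1cccc2ccc(N)nc12` has not yet been measured in this assay. It differs from compound 1 as follows: 1,2-dimethylpropyl in place of cyclopentylmethyl on an oxygen on an aromatic ring. Among the compounds with values here, no measured step of this kind exists; a loss of potency is expected, a step of a 2.8-fold higher number from compound 1 to compound 3 (0.45 log units; beyond the scatter) somewhat beyond the scatter. Compound 3 is therefore estimated at 150 nM in this assay, within 40 nM to 600 nM.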

Compound 3, half-maximal inhibitory concentration: 199 nM
Compound 3: the middle estimate sits 1.3-fold (0.12 log units) below what was measured; low and high end bracket the measured number.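

On the oxygen on an aromatic ring of the shared core, 1,2-dimethylpropyl in place of cyclopentylmethyl gives a 3.8-fold higher number from compound 1 to compound 3 (0.57 log units; beyond the scatter) in this assay. The position therefore accepts a side chain with no ring and still gives a measured value, although the ring-bearing cyclopentylmethyl gives the lower number. Nothing shown here accounts for the size of this step.

Going by these compounds, whether the loss follows from removing the ring or from the branching stays open. Neither a straight pentyl chain nor cyclohexylmethyl on this oxygen appears among the compounds shown.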